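A few compounds are considered here, and "the series" means these few. Any claim that something is new, unique, unknown or untested is made for them only; others in the source may bear on it.

Measured so far in a functional assay (muscle tissue) with Cavia porcellus as the target; on this read-out lower numbers stand for an effect already at smaller amounts and higher numbers for an effect only at larger amounts of compound:

compound 1, `COC(=O)C1=C(C)N=C(C)/C(=C(\O)OC)C1c1ccc(Cl)cc1`: 8130 nM
compound 2, `COC(=O)C1=C(C)N=C(C)/C(=C(\O)OC)C1c1ccccc1I`: 46.8 nM
compound 3, `COC(=O)C1=C(C)N=C(C)/C(=C(\O)OC)C1c1ccccc1F`: 42.7 nM

Compound 1 has the highest number of the three in this assay; its nearest neighbour is compound 2, at a 170-fold lower number from compound 1 to compound 2 (2.24 log units; beyond the scatter), and the furthest is compound 3, at a 190-fold lower number from compound 1 to compound 3 (2.28 log units; beyond the scatter). Between compound 2 and compound 3 the step is a 1.1-fold lower number from compound 2 to compound 3 (0.04 log units; within the scatter), so the two differ only within the scatter.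

Compound 4, `CCc1ccccc1C1C(C(=O)OC)=C(C)N=C(C)/C1=C(\O)OC`, has not yet been measured in this assay. It differs from compound 1 as follows: 2-ethylphenyl in place of 4-chlorophenyl on a saturated ring carbon.

Among the compounds with values here, two measured steps bear on this change, both starting from compound 1 and both replacing the 4-chlorophenyl group with a phenyl ring carrying a single substituent at the 2-position: a 170-fold lower number from compound 1 to compound 2 (2.24 log units; beyond the scatter) and a 190-fold lower number from compound 1 to compound 3 (2.28 log units; beyond the scatter). In those steps the nature of the 2-substituent made no difference beyond the scatter, iodo and fluoro giving near-identical numbers. A 2-ethylphenyl group has not been tried, and the data hold no carbon-only substituent at that position, so the expectation rests on the two halogen cases alone. A large drop from compound 1 to compound 4 is therefore expected, with somewhat wider uncertainty than the measured pair shows; the expected step is a 140-fold lower number from compound 1 to compound 4 (2.13 log units; beyond the scatter). For compound 4 the estimated value is 60 nM, expected to lie between 15 nM and 300 nM.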

Compound 4, half-maximal effective concentration: 6.46 nM
For compound 4 the middle estimate is 9.3-fold (0.97 log units) above the measured one; measured number outside the range, below it.
By their numbers in this assay, from the lowest: compound 4; then compounds 3 and 2 (each within the scatter of the next); then compound 1.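

Iodo and fluoro could not be told apart at the 2-position of the phenyl ring in this assay, but the substituent there does matter once ethyl is included: ethyl in place of fluoro gives a 6.6-fold lower number from compound 3 to compound 4 (0.82 log units; beyond the scatter), and ethyl in place of iodo gives a 7.2-fold lower number from compound 2 to compound 4 (0.86 log units; beyond the scatter). The full change from 4-chlorophenyl to 2-ethylphenyl (a 1300-fold lower number from compound 1 to compound 4 (3.10 log units; beyond the scatter)) therefore goes further than either halogen step from the same starting point, so the large drop seen with the halogens does not mark the limit for this position. No available data explain the advantage of ethyl over the two halogens.

Compound 1 differs from the other three compounds in both the substituent and its place on the phenyl ring, so the shown data cannot separate those two contributions; 2-chlorophenyl and 4-ethylphenyl would divide the step. From the compounds shown here alone, it also remains open whether the trend continues with a longer chain such as propyl or reverses with a methoxy group at the 2-position.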